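The source may hold more compounds than are shown below. What is called first, only, known or untested is meant among the compounds shown, and "the series" means these compounds.

Measured in a functional assay on HO8910 cells (Homo sapiens) for inhibition, read by MTT assay, with a stated time of 24 h, tested at 0.1 ug/mL; a lower number here means less inhibition of growth, a higher number more inhibition of growth at the concentration tested:

Compound 1 `O=C(CCCCC1CCSS1)Nc1ccc(Br)cn1`: "not active" (no number reported)
Compound 2 `O=C(CCCCC(S)CCS)Nc1ccccn1`: "not active" (no number reported)
Compound 3 `O=C(CCCCC(S)CCS)Nc1ccc(Cl)cn1`: 2.65%

Only one of these three entries is a number. In this assay, compound 3 gives 2.65%, a small figure on a percentage read-out, while compound 1 and compound 2 were reported without a number. Among the measured compounds shown here, compound 3 therefore has no numerical neighbour against which its place could be judged, and the series so far shows very little growth inhibition at the concentration tested.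

The next compound to be tested is compound 4 `O=C(CCCCC(S)CCS)Nc1ccc(Br)cn1`, which carries bromo in place of chloro on an aromatic carbon. For the measured compounds named here, the rest of the structure stays the same, and no measured pair in this small set shows what such an exchange does. Going by the values given here, with no such step to draw on, the expectation rests on compound 3 at 2.65% and on the small size of the change. The expected result is a number 1.4 percentage points higher from compound 3 to compound 4 (within the scatter), with no shift beyond the usual scatter and no firm direction. A report of no activity would also not be a surprise. The estimated value for compound 4 is 4%, with an expected range from 0% to 14%.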

Compound 4, percent growth inhibition at one concentration: "not active" (no number reported)
The entry for compound 4 holds no number; there is nothing to compare the estimate with.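

In this assay compound 4 carries no number, so no step can be read between compound 3 and compound 4. No measured information bears on this result. The compounds shown leave open what bromo in place of chloro does to growth inhibition at the concentration tested.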